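The compounds below may be only part of what the source reports. "The series", "measured", "known", "first", "only" and "open" are said of these compounds alone.

Compound 1 `COc1cc(/C=C(/SCc2ccc(Br)cc2)C(=O)c2ccc(C(=O)O)cc2)ccc1F`: 1000 nM
Compound 2 `COc1cc(OC)c(/C=C(\C(=O)c2ccc([N+](=O)[O-])cc2)S(=O)(=O)Cc2ccc(Cl)cc2)c(OC)c1`: 10000 nM

In a functional assay on DU-145 cells (Homo sapiens) for inhibition, read by trypan blue exclusion, with a stated time of 96 h (on this read-out higher numbers stand for weaker inhibition of growth and lower numbers for stronger inhibition of growth), compound 1 holds the lower of the two numbers at 1000 nM, and so shows the stronger inhibition of growth. Compound 2 is the nearest and only neighbour at 10000 nM, a gap well beyond the scatter. Compound 3 `O=C(O)c1ccc(C(=O)/C(=C\c2ccc(O)c(Br)c2)SCc2ccc(Br)cc2)cc1` has yet to be measured. It departs from compound 1 in one place: 3-bromo-4-hydroxyphenyl in place of 4-fluoro-3-methoxyphenyl on a double-bonded chain carbon bound to a double-bonded chain carbon. There, 3-bromo-4-hydroxyphenyl stands in place of 4-fluoro-3-methoxyphenyl on a double-bonded chain carbon bound to a double-bonded chain carbon. Going by the values given here, no measured pair of compounds isolates a change in one place, so the data offer no direct guide, and the expectation stays anchored on compound 1 at 1000 nM. The expected no change at the digits printed from compound 1 to compound 3 (within the scatter) lies within the scatter, with neither direction favoured. For compound 3 the estimated value is 1000 nM, with an expected range of 300 nM to 4000 nM.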

Compound 3, concentration for 50% growth inhibition: 25000 nM
Compound 3: the middle estimate sits 25-fold (1.40 log units) below what was measured; measured number above the stated range.
By their numbers in this assay, from the lowest: compound 1; then compound 2; then compound 3.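

In this assay the group on a double-bonded chain carbon bound to a double-bonded chain carbon proves far from silent: 3-bromo-4-hydroxyphenyl in place of 4-fluoro-3-methoxyphenyl gives a 25-fold higher number from compound 1 to compound 3 (1.40 log units; beyond the scatter) and so much weaker inhibition of growth. This is the first change in one place among these compounds, and it shows how far this position alone can move the number when a group with a hydrogen-bond donor replaces one without. Nothing available bears on why the number rises.

The step exchanges the bromine and hydroxyl for the fluorine and methoxy all at once, so the compounds leave open which of these parts accounts for the weaker inhibition. They also leave open whether a plain phenyl or a phenyl carrying an amine at this place would stay close to compound 1.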